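Cycloheptyl in place of thiophen-2-yl: compound 3

This account rests on a few compounds, and the source may have more. Where it says the series, first, only, none or still open, it means among the compounds named here.

In a functional assay on MCF7 cells (Homo sapiens) for cytotoxicity, read by WST assay, with a stated time of 72 h (on this read-out lower numbers stand for stronger inhibition and higher numbers for weaker inhibition), compound 1 `COc1ccc(C2(c3ccc(O)cc3)C(=O)Nc3c2ccc(F)c3F)cc1` gives 2.1 nM; 6.3 nM; > 1000 nM (3 entries). Compound 2 `O=C1Nc2c(ccc(F)c2F)C1(c1ccc(O)cc1)c1cccs1` stands at 82 nM, the only number shown for it, with one further entry lacking a single number. Compound 3 `O=C1Nc2c(ccc(F)c2F)C1(c1ccc(O)cc1)C1CCCCCC1` carries cycloheptyl in place of thiophen-2-yl on a saturated ring carbon. Within the data shown here, no measured step in this assay tests this change, which leaves the expectation loose. A loss of potency beyond the scatter is expected, a 3.0-fold higher number from compound 2 to compound 3 (0.48 log units; beyond the scatter). Compound 3 is estimated at 250 nM, with an expected range of 40 nM to 1500 nM.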

Compound 3, half-maximal inhibitory concentration: 1.2 nM
Beside the measured number, compound 3's estimate is 210-fold (2.32 log units) above it; measured number outside the range, below it.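

In this assay, the saturated ring carbon two ring bonds from the ring nitrogen accepts a non-aromatic ring of carbon only: cycloheptyl in place of thiophen-2-yl gives a 68-fold lower number from compound 2 to compound 3 (1.83 log units; beyond the scatter) on the shared core. A low number at this position therefore needs neither an aromatic ring nor the sulfur of thiophen-2-yl. Compound 1 offers no single reference for this position, and one of its entries is a limit of the assay: the several entries of compound 1 in this assay, 2.1 nM; 6.3 nM; > 1000 nM (3 entries)

Cyclopentyl or cyclohexyl at this carbon would separate ring size from the loss of the aromatic ring. From the compounds shown here alone, how an amine on the cycloheptyl ring would read remains open.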